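A few compounds are considered here, and "the series" means these few. Any claim that something is new, unique, unknown or untested is made for them only; others in the source may bear on it.

Measured so far in an in vitro functional assay on HEK293-A cells for antagonist activity at metabotropic glutamate receptor 5 (Rattus norvegicus), read by calcium flux; on this read-out lower numbers stand for stronger inhibition and higher numbers for weaker inhibition:
compound 1, `N#Cc1cc(F)cc(C(=O)Nc2cccc(F)c2)c1`: 2160 nM
compound 2, `N#Cc1cc(F)cc(C(=O)Nc2cccc(Cl)c2)c1`: 45 nM
compound 3, `N#Cc1cccc(NC(=O)c2cc(F)cc(C#N)c2)c1`: 489 nM

The three compounds share one amide core and differ only in a single group on an aromatic carbon. In this assay compound 3 holds the second highest number of the three: the change of fluoro to cyano gave a 4.4-fold lower number from compound 1 to compound 3 (0.65 log units; beyond the scatter), while the change of chloro to cyano gave an 11-fold higher number from compound 2 to compound 3 (1.04 log units; beyond the scatter). Compound 4, `CC(C)(C)c1cccc(NC(=O)c2cc(F)cc(C#N)c2)c1`, carries the next change at this same place: tert-butyl in place of cyano on an aromatic carbon.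

For the measured compounds named here, no measured step involves tert-butyl, so the bearing steps are indirect. They show that the group at this position matters greatly, since a 48-fold lower number from compound 1 to compound 2 (1.68 log units; beyond the scatter) was large and an 11-fold higher number from compound 2 to compound 3 (1.04 log units; beyond the scatter) was large as well, while a 4.4-fold lower number from compound 1 to compound 3 (0.65 log units; beyond the scatter) was modest. Whether tert-butyl behaves more like chloro or more like fluoro cannot be read from these three compounds, so the direction of the step is uncertain and a wide range is appropriate.

Compound 4 is therefore estimated at 300 nM in this assay, within a range from 40 nM to 2500 nM. This estimate means an expected step of a 1.6-fold lower number from compound 3 to compound 4 (0.21 log units; within the scatter) from compound 3.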

Compound 4, half-maximal inhibitory concentration: > 30000 nM
Compound 4 ended at the assay's limit; the forecaster's own chance of this, stated with the estimate: 5%; middle value at least 100-fold (2.00 log units) away from the limit.
By their numbers in this assay, from the lowest: compound 2; then compound 3; then compound 1. At a limit, above all of these: compound 4.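

Compound 4 sits at a limit of the assay, not at a number: the limit of > 30000 nM in this assay, at which 1 of the 4 values shown sits.

Every step to it is therefore a minimum, and all three are large: an at least 61-fold higher number from compound 3 to compound 4 (1.78 log units; beyond the scatter), an at least 660-fold higher number from compound 2 to compound 4 (2.82 log units; beyond the scatter) and an at least 13-fold higher number from compound 1 to compound 4 (1.14 log units; beyond the scatter). So this position does not accept every group: fluoro, chloro and cyano each gave a measured number, whereas tert-butyl did not, and it ends above even the weakest of them, the fluoro compound 1.

The compounds shown leave open where between chloro and tert-butyl the loss sets in, for instance whether methyl, bromo or trifluoromethyl at this place would stay close to chloro or fall away as tert-butyl does. They also leave open how an isopropyl group or a methoxy group would behave here.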